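The compounds below may be only part of what the source reports. "The series", "measured", "known", "first", "only" and "open" are said of these compounds alone.

Compound 1 `COC(=O)/C(=C\c1ccc(OC(=O)c2ccc(OC)cc2)cc1)Sc1ccnc2cc(Cl)ccc12`: 63500 nM
Compound 2 `COC(=O)/C(=C\c1ccc(OC(=O)c2ccc(OC)cc2OC)cc1)Sc1ccnc2cc(Cl)ccc12`: 41600 nM
Compound 3 `COC(=O)/C(=C\c1ccc(OC(=O)c2cc(OC)c(OC)cc2OC)cc1)Sc1ccnc2cc(Cl)ccc12`: 52500 nM

All three values come from an ADME assay on cells (Lymphocyte, Homo sapiens) for cytotoxicity, read by MTT assay, with a stated time of 48 h; a higher number here means a weaker inhibitor, a lower number a stronger inhibitor. The compounds share one core and differ only in the methoxy groups on the aromatic ring carried by a carbonyl carbon. Compound 3 lies within the usual scatter of both other compounds, so the three cannot be ranked.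

Compound 4 `COC(=O)/C(=C\c1ccc(OC(=O)c2cc(OC)c(OC)c(OC)c2)cc1)Sc1ccnc2cc(Cl)ccc12` has the same atoms as compound 3, joined differently: 3,4,5-trimethoxyphenyl in place of 2,4,5-trimethoxyphenyl on a carbonyl carbon. In words, 3,4,5-trimethoxyphenyl stands in place of 2,4,5-trimethoxyphenyl on a carbonyl carbon. Among the measured compounds shown here, no measured pair makes exactly this swap, so the nearest evidence is the set of methoxy changes: a 1.5-fold lower number from compound 1 to compound 2 (0.18 log units; within the scatter), a 1.3-fold higher number from compound 2 to compound 3 (0.10 log units; within the scatter) and a 1.2-fold lower number from compound 1 to compound 3 (0.08 log units; within the scatter). None of these steps rises above the scatter, so no real shift is expected from moving a methoxy group in this assay. The expected step is a 1.1-fold lower number from compound 3 to compound 4 (0.02 log units; within the scatter), which is no change beyond the scatter. For compound 4 the estimated value is 50000 nM, with an expected range from 28000 nM to 85000 nM.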

Compound 4, half-maximal inhibitory concentration: 35200 nM
Beside the measured number, compound 4's estimate is 1.4-fold (0.15 log units) above it, and the stated range covers the measured number.
By their numbers in this assay, from the lowest: compounds 4, 2, 3 and 1 (each within the scatter of the next).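

Rearranging the same three methoxy groups into 3,4,5-trimethoxyphenyl on a carbonyl carbon gives a 1.5-fold lower number from compound 3 to compound 4 (0.17 log units; within the scatter) in this assay, so the arrangement of these groups, and not only their number, has now been tested without a shift beyond the scatter. Compared with the two compounds carrying fewer methoxy groups, the same group gives a 1.2-fold lower number from compound 2 to compound 4 (0.07 log units; within the scatter) and a 1.8-fold lower number from compound 1 to compound 4 (0.26 log units; within the scatter) and so even the widest gap among the four compounds stays inside the scatter. No measurement shown offers an explanation for these numbers.

On these data alone, every compound here carries only methoxy groups on this ring, so it remains open whether an amine, a carboxylic acid or a longer chain such as butoxy would move the number beyond the scatter. The same question stands for a plain phenyl ring with no methoxy group at all.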